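This account rests on a few compounds, and the source may have more. Where it says the series, first, only, none or still open, it means among the compounds named here.

In a functional assay on CWR22R cells (Homo sapiens) for inhibition, read by sulforhodamine B assay, with a stated time of 72 h (on this read-out higher numbers stand for weaker inhibition and lower numbers for stronger inhibition), three compounds with a shared core have been measured. Compound 1 `COc1ccc(Cn2nnc(O)c2C(=O)Nc2cc(C(F)(F)F)cc(C(F)(F)F)c2)cc1` gives 33800 nM, compound 2 `COc1ccc(Cn2nnc(O)c2C(=O)Nc2ccc(-c3ccccc3)cc2)cc1` gives 57900 nM, and compound 3 `COc1ccc(Cn2nnc(O)c2C(=O)Nc2cccc(-c3ccccc3)c2)cc1` gives 52100 nM. Compound 3 stands within the usual scatter of both compound 1 and compound 2, so these numbers do not separate the three compounds.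

Compound 4 `COc1ccc(Cn2nnc(O)c2C(=O)Nc2cccc(-c3cccc(O)c3)c2)cc1` is compound 3 with one change, hydroxy in place of hydrogen on an aromatic carbon, which turns phenyl into 3-hydroxyphenyl. Going by the values given here, no two measured compounds differ in only one place, so the data show no step for a change of this kind. Compound 1 carries trifluoromethyl groups instead of a phenyl, yet compound 1 at 33800 nM and compound 3 at 52100 nM remain within the scatter of each other. On that basis, a single added hydroxy is expected to give only a small step in this assay, with no firm direction and nothing beyond the scatter. The expected step is a 1.2-fold lower number from compound 3 to compound 4 (0.06 log units; within the scatter). For compound 4 the estimated value is 45000 nM, with an expected range from 20000 nM to 100000 nM.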

Compound 4, half-maximal inhibitory concentration: 75700 nM
The estimate for compound 4 lay 1.7-fold (0.23 log units) below the measured number; measured number inside the range.
By their numbers in this assay, from the lowest: compounds 1, 3, 2 and 4 (each within the scatter of the next, the first and the last beyond it).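

In this assay the series now holds its first step between compounds that differ in one place: hydroxy in place of hydrogen on an aromatic carbon, which turns phenyl into 3-hydroxyphenyl, gives a 1.5-fold higher number from compound 3 to compound 4 (0.16 log units; within the scatter) and so does not separate the two compounds. Going by these compounds alone, at this place on the outer six-membered aromatic ring, meta to a large group, the added hydroxy therefore brings no step that can be told apart from repeated measurement, and no direction can be assigned to it from this single pair. Nothing measured here speaks to the reason for this result.

As far as these compounds go, whether an amine, a carboxylic acid or a methoxy group on that same carbon would give a step beyond the scatter remains open. From the compounds shown here alone, it is also open whether hydroxy on the phenyl of compound 2 would give a similarly small step, since this one pair describes only the phenyl of compound 3.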